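Methoxy on compound 2 in a toxicity test

This account rests on a few compounds, and the source may have more. Where it says the series, first, only, none or still open, it means among the compounds named here.

Compound 1 `COc1cccc2cc(CSc3nc4cncnc4n3[C@@H]3O[C@H](CO)[C@@H](O)[C@H]3O)c(=O)oc12` gives 47000 nM
Compound 2 `Nc1ncnc2c1nc(SCc1cc3ccccc3oc1=O)n2[C@@H]1O[C@H](CO)[C@@H](O)[C@H]1O` gives 49000 nM

Both values come from a functional assay on Huh-5-2 cells (Homo sapiens) for cytotoxicity, read by microscopy (on this read-out lower numbers stand for higher toxicity in this test and higher numbers for lower toxicity in this test), and lie within the usual scatter of each other, so compound 2 stands level with compound 1 on these numbers. Compound 3 `COc1cccc2cc(CSc3nc4c(N)ncnc4n3[C@@H]3O[C@H](CO)[C@@H](O)[C@H]3O)c(=O)oc12` has methoxy in place of hydrogen on an aromatic carbon. For the measured compounds named here, no measured pair shows what this change does here, so only a small effect can be assumed. The estimated step is a 1.1-fold lower number from compound 2 to compound 3 (0.04 log units; within the scatter) and is expected to stay within the scatter, with no firm direction. In this assay compound 3 is expected at 45000 nM with 20000 nM to 100000 nM as the estimated range.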

Compound 3, half-maximal cytotoxic concentration: > 103000 nM
Compound 3: only a limit was reported; the forecaster's own chance of this, stated with the estimate: 20%; at least 2.2-fold (0.35 log units) between middle value and limit.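

Methoxy in place of hydrogen on an aromatic carbon gives an at least 2.1-fold higher number from compound 2 to compound 3 (0.32 log units; beyond the scatter) in this assay, and an added amino group gives an at least 2.1-fold higher number from compound 1 to compound 3 (0.34 log units; beyond the scatter), so both single changes point towards lower toxicity in this test. The result for compound 3 is a limit and not a number: the limit of > 103000 nM in this assay, at which 1 of the 3 values shown sits. Both steps are therefore minimum sizes, and their full size cannot be read. As far as these compounds go, whether ethoxy or a carboxylic acid on that aromatic carbon would move the number the same way stays open.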